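This account rests on a few compounds, and the source may have more. Where it says the series, first, only, none or still open, it means among the compounds named here.

Three compounds share one core and differ only in the ring that sits on a saturated chain carbon, two bonds along the chain from an oxygen on a saturated carbon. Compound 1 `CCO/C(O)=C1\C(COCCN2CC(=O)NC2=O)=NC(C)=C(C(=O)OC)C1c1ccccc1Cl` gives 20 nM in a functional assay (aorta) with Rattus norvegicus as the target; a lower number here means a stronger inhibitor, a higher number a weaker inhibitor. Compound 2 `CCO/C(O)=C1\C(COCCN2CC(=O)N=C2N)=NC(C)=C(C(=O)OC)C1c1ccccc1Cl` gives 20 nM in this assay, and the step of no change at the digits printed from compound 1 to compound 2 (within the scatter). Compound 3 `CCO/C(O)=C1\C(COCCn2cc(N)nc2O)=NC(C)=C(C(=O)OC)C1c1ccccc1Cl` gives 31.6 nM in this assay; its number is the highest of the three, yet the steps of a 1.6-fold higher number from compound 1 to compound 3 (0.20 log units; within the scatter) and a 1.6-fold higher number from compound 2 to compound 3 (0.20 log units; within the scatter) both stay within the scatter, so these three compounds cannot be told apart on the numbers at hand.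

Compound 4 `CCO/C(O)=C1\C(COCCn2cnc3ccccc32)=NC(C)=C(C(=O)OC)C1c1ccccc1Cl` has not yet been measured. It differs from compound 3 by 1H-benzimidazol-1-yl in place of 4-amino-2-hydroxy-1H-imidazol-1-yl on a saturated chain carbon, two bonds along the chain from an oxygen on a saturated carbon. The measured steps that bear on this change are the two ring swaps at the same place, from compound 1 and from compound 2 to compound 3, and neither moved the number beyond the scatter. A step in this assay of about a 1.1-fold lower number from compound 3 to compound 4 (0.02 log units; within the scatter) is therefore expected, which is no change beyond the scatter. Compound 4 is estimated at 30 nM in this assay, with an expected range from 10 nM to 100 nM.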

Compound 4, half-maximal inhibitory concentration: 20 nM
Compound 4: middle estimate off by 1.5-fold (0.18 log units), on the high side; measured number inside the range.
By their numbers in this assay, from the lowest: compounds 1, 2, 4 and 3 (each within the scatter of the next).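

In this assay the steps of a 1.6-fold lower number from compound 3 to compound 4 (0.20 log units; within the scatter) and no change at the digits printed from compound 2 to compound 4 (within the scatter) and no change at the digits printed from compound 1 to compound 4 (within the scatter) show that this place, on a saturated chain carbon, two bonds along the chain from an oxygen on a saturated carbon, also accepts 1H-benzimidazol-1-yl without a change beyond the scatter. The group that enters adds a six-membered aromatic ring of carbon only and has 0 hydrogen-bond donors, against 2 in the group it replaces. No accompanying measurement offers an explanation for this result.

All four groups shown contain a five-membered ring with 2 hetero atoms and sit on the same 2-substituted ethoxy chain. A simple amine, a carboxylic acid or a longer chain at this place therefore remains an open question.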